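This account rests on a few compounds, and the source may have more. Where it says the series, first, only, none or still open, it means among the compounds named here.

Going by the values given here, in an ADME assay on HepG2 cells (Homo sapiens) for cytotoxicity, with a stated time of 72 h (on this read-out higher numbers stand for an effect only at larger amounts of compound and lower numbers for an effect already at smaller amounts), compound 1 `CC(=O)c1ccc(NC(=O)Nc2cc(C)nc3ccccc23)cc1` gives 19000 nM as the only true number so far. Compound 2 `Cc1cc(NC(=O)Nc2cccc([N+](=O)[O-])c2)c2ccccc2n1` reads > 25000 nM and that is a limit of the assay, not a number. Compound 3 `Cc1cc(NC(=O)Nc2cc(F)cc(F)c2)c2ccccc2n1` reads > 25000 nM and that too is a limit. With the limit of > 25000 nM in this assay, at which 2 of the 3 values shown sit, as the backdrop, compound 1 cannot be ranked against the other two.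

Compound 4 `Cc1cc(NC(=O)Nc2ccc(C(N)=O)cc2)c2ccccc2n1` keeps the core of compound 1 and swaps one group, acetyl to carbamoyl, which means amino in place of methyl on a carbonyl carbon and nothing else. Among the compounds with values here, no measured pair shows what this swap does here, so the only anchor is compound 1 at 19000 nM in this assay and the expectation is no shift beyond the usual scatter. The estimated step of a 1.3-fold higher number from compound 1 to compound 4 (0.12 log units; within the scatter) is therefore small, and the assay may again return only a limit. Compound 4 is expected at 25000 nM with an estimated range from 11000 nM to 50000 nM in a measurement still to come.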

Compound 4, half-maximal effective concentration: > 25000 nM
Compound 4: a limit, no number; the forecaster's own chance of this, stated with the estimate: 60%; the middle value lies on the limit itself.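

Going by these compounds alone, this is the first pair in this assay that differs in one place, and amino in place of methyl on a carbonyl carbon gives an at least 1.3-fold higher number from compound 1 to compound 4 (0.11 log units; that floor lies within the scatter). Compound 4 reads > 25000 nM, which is a limit of the assay and not a number. The change therefore gives no sign of an effect at smaller amounts of compound, but the full size of the step stays hidden and it may lie within the scatter or beyond it, since only its floor can be read: the limit of > 25000 nM in this assay, at which 3 of the 4 values shown sit.

As far as these compounds go, what a carboxylic acid or a longer chain such as ethyl would do on the same carbonyl carbon remains open. From the compounds shown here alone, it is also open whether any change at this place gives a lower number than that of compound 1.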